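From compound 2 to compound 3: one more fluoro

A few compounds are considered here, and "the series" means these few. Any claim that something is new, unique, unknown or untested is made for them only; others in the source may bear on it.

Compound 1 `FC(F)(F)c1cccc(-c2nc3cnc(Nc4ccccn4)cc3[nH]2)c1`: < 5000 nM (a limit)
Compound 2 `Fc1ccc(-c2nc3cnc(Nc4ccccn4)cc3[nH]2)cc1C(F)(F)F`: < 5000 nM (a limit)

In a physicochemical assay for solubility, using the shake flask method, in phosphate buffer, measured as kinetic solubility, with a stated time of 20 h, at pH 6.5 (on this read-out higher numbers stand for higher solubility and lower numbers for lower solubility), compound 2 gives < 5000 nM as a limit, not a number. The measured record offers only this (the limit of < 5000 nM in this assay, at which 2 of the 2 values shown sit). Compound 3 `Fc1ccc(Nc2cc3[nH]c(-c4ccc(F)c(C(F)(F)F)c4)nc3cn2)nc1` carries fluoro in place of hydrogen on an aromatic carbon, turning (pyridin-2-yl)amino into (5-fluoropyridin-2-yl)amino (fluoro in place of hydrogen on an aromatic carbon). Among the measured compounds shown here, the one measured step of this kind (a step that the two limits leave unreadable from compound 1 to compound 2) offers no size or direction to carry over. No step beyond the scatter is therefore expected (a step that the limit leaves unreadable from compound 2 to compound 3). For compound 3 the estimated value is 2500 nM (expected range 800 nM to 6000 nM).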

Compound 3, solubility: < 5000 nM
Compound 3: only a limit was reported (the forecaster's own chance of this, stated with the estimate: 85%); the middle value does not contradict the limit.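

In this assay compound 3 gives < 5000 nM, which is a limit and not a number, so no step can be read from compound 2 to compound 3. Going by these compounds, whether compound 1, compound 2 and compound 3 differ at all in this assay remains open.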